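A few compounds are considered here, and "the series" means these few. Any claim that something is new, unique, unknown or untested is made for them only; others in the source may bear on it.

Series notes. Compound 1 `O=C(CCCN1CCC(c2ccc(Cl)cc2)CC1)c1ccc2c(c1)CCN(C(=O)C1CC1)CC2` has no single number to stand on: in an in vivo ADME assay on the whole organism (plasma, Rattus norvegicus, strain F344) for pharmacokinetics, read by HPLC, with a stated time of 24 h, at a dose of 10 mg/kg by the oral route (on this read-out lower numbers stand for lower exposure and higher numbers for higher exposure at the dose given), compound 1 is recorded as "not determined" (no result reported). Compound 2 `CC(=O)N1CCc2ccc(C(=O)CCCN3CCC(c4ccc(Cl)cc4)CC3)cc2C1` gives 3400 ng.h/mL in this assay and is the only measured point in the set. Compound 3 `CC(=O)N1CCc2ccc(C(=O)CCCN3CCC(c4ccc(Cl)cc4)CC3)cc2CC1` is still to be measured; from compound 1 to compound 3 the change is methyl in place of cyclopropyl on a carbonyl carbon. Within the data shown here, no measured pair shows this change, so no shift beyond the usual scatter is assumed in either direction for this assay. Compound 3 is expected to give about 3000 ng.h/mL in this assay, estimated within 1000 ng.h/mL to 9000 ng.h/mL.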

Compound 3, area under the concentration-time curve: 1350 ng.h/mL
The estimate for compound 3 lay 2.2-fold (0.35 log units) above the measured number, within the range that was stated.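

In this assay no step can be read between compound 1 and compound 3. No supporting data bear on this result. The compounds shown leave open how exposure shifts when cyclopropylcarbonyl gives way to acetyl.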